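The source may hold more compounds than are shown below. What is called first, only, known or untested is meant among the compounds shown, and "the series" means these compounds.

Measured compounds in an assay on CHO cells for binding affinity to Melanocortin receptor 4 (Homo sapiens); a lower number here means a stronger inhibitor, a higher number a weaker inhibitor:
Compound 1, `COc1ccc(-n2nc(Sc3ccc(Cl)cc3)cc(CC[C@@H](C)NC(=O)[C@H]3CNCC[C@@H]3c3cccc(Cl)c3)c2=O)cc1`, gives 43 nM.
Compound 2, `COc1ccc(-n2nc(Sc3ccc(Cl)cc3)cc(CC[C@@H](C)NC(=O)[C@H]3CNCC[C@@H]3c3ccc(Cl)cc3Cl)c2=O)cc1`, gives 3.2 nM.
Compound 3, `COc1ccc(-n2nc(Sc3ccc(Cl)cc3)cc(CC[C@@H](C)NC(=O)[C@H]3CCNC[C@@H]3c3ccc(Cl)cc3)c2=O)cc1`, gives 58 nM.

Compound 3 stands at the highest of the three numbers. Its gap to compound 1 is within the scatter, so the two cannot be told apart; compound 2 lies well below compound 3, and that gap is beyond the scatter.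

Compound 4, `COc1ccc(-n2nc(Sc3ccc(Cl)cc3)cc(CC[C@@H](C)NC(=O)[C@H]3CCNC[C@@H]3c3ccc(F)cc3)c2=O)cc1`, differs from compound 3 in one place: fluoro in place of chloro on an aromatic carbon, which cut one bond further out reads 4-chlorophenyl to 4-fluorophenyl. Going by the values given here, the only step measured so far, a 13-fold lower number from compound 1 to compound 2 (1.13 log units; beyond the scatter), swaps one chlorinated phenyl for another on the saturated ring carbon and shows that this phenyl matters a great deal in this assay. Among the compounds with values here, it does not, however, contain a chloro-to-fluoro exchange, so no measured step bears directly on the change from compound 3 to compound 4. The expectation therefore rests on the change being a single halogen swap: a modest step, expected to lie at or just beyond the scatter, toward a higher number, a 2.1-fold higher number from compound 3 to compound 4 (0.32 log units; beyond the scatter). Compound 4 is expected to give about 120 nM, with a range from 40 nM to 400 nM.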

Compound 4, half-maximal inhibitory concentration: 66 nM
For compound 4 the middle estimate is 1.8-fold (0.26 log units) above the measured one; low and high end bracket the measured number.
By their numbers in this assay, from the lowest: compound 2; then compounds 1, 3 and 4 (each within the scatter of the next).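

In this assay the change from 4-chlorophenyl to 4-fluorophenyl gives a 1.1-fold higher number from compound 3 to compound 4 (0.06 log units; within the scatter) and so leaves the two halogens indistinguishable at this position, an aromatic carbon para to a large group. The earlier result, a 13-fold lower number from compound 1 to compound 2 (1.13 log units; beyond the scatter) on a different core, involved a different pattern of chlorines on the phenyl and showed that this phenyl can matter greatly, whereas this pair shows that on the core of compound 3 one halogen can take the place of the other with no effect that can be read beyond the scatter. No measurement at hand gives a reason for this result.

Going by these compounds, it remains open whether the same position would accept a group other than a halogen, such as methoxy, trifluoromethyl or a nitrile, or a bare phenyl with no group there at all. On these data alone, it is also open whether the 2,4-dichlorophenyl of compound 2 would bring a comparably large step on the core shared by compound 3 and compound 4.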